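A methoxy for the amino on the monophosphate core

The compounds below may be only part of what the source reports. "The series", "measured", "known", "first", "only" and "open" are said of these compounds alone.

Measured compounds:
compound 1 `O=c1[nH]c(=S)ccn1[C@@H]1O[C@H](COP(=O)(O)O)[C@@H](O)[C@H]1O` gives > 100000 nM in an in vitro functional assay on 1321-N1 cells for agonist activity at P2Y purinoceptor 2 (Homo sapiens), read by scintillation proximity assay and inositol phosphate accumulation (a lower number here means that less compound is needed, a higher number that more compound is needed for the effect), a limit of the assay.
compound 2 `Nc1nc(=O)ccn1[C@@H]1O[C@H](COP(=O)(O)O)[C@@H](O)[C@H]1O` gives > 100000 nM in this assay, a limit of the assay.
compound 3 `CCCSc1nc(=O)ccn1[C@@H]1O[C@H](COP(=O)(O)OP(=O)(O)O)[C@@H](O)[C@H]1O` gives 1200 nM in this assay.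

Compound 2 stands at the limit of this assay: the value > 100000 nM for compound 2 is a limit and not a number. Compound 1 sits at the limit of > 100000 nM in this assay, at which 2 of the 3 values shown sit, as well. For the measured compounds named here, compound 3, which carries a propylthio group and a second phosphate on its sugar, is the one compound of the three with a measured number in this assay.

Compound 4 `COc1nc(=O)ccn1[C@@H]1O[C@H](COP(=O)(O)O)[C@@H](O)[C@H]1O` arises from compound 2 by methoxy in place of amino on an aromatic carbon. Going by the values given here, no step joining two measured compounds is available that would set the size of such a change, and the starting point is itself a limit. The step of a number no higher from compound 2 to compound 4 (the limit leaves the size open) is therefore an expectation of no move beyond the scatter, with a further limit the most likely outcome. Compound 4 is estimated at 100000 nM in this assay, expected to fall within 20000 nM to 300000 nM.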

Compound 4, half-maximal effective concentration: 9900 nM
Compound 4: the middle estimate sits 10-fold (1.00 log units) above what was measured; measured number outside the range, below it.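

In this assay, the group on the aromatic carbon between two ring nitrogen atoms proves able to move the read-out on the monophosphate core: methoxy in place of amino gives an at least 10-fold lower number from compound 2 to compound 4 (1.00 log units; beyond the scatter). Of the compounds with a single phosphate on the sugar, compound 4 alone gives a measured number, so a monophosphate on this core is not in itself enough to hold a compound at the limit. The value of compound 2 is a limit of the assay and not a number, so the step sets only a smallest size and its true size remains unknown: the limit of > 100000 nM in this assay, at which 2 of the 4 values shown sit.

The compounds shown do not tell whether the change in read-out follows from the loss of the amino group or from the arrival of the methoxy group, nor how an ethoxy group, a methylthio group or a dimethylamino group would read at this place. They also leave open what a second phosphate on the sugar would do for the methoxy compound, and whether a longer chain such as propoxy would change the read-out further.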